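This account rests on a few compounds, and the source may have more. Where it says the series, first, only, none or still open, it means among the compounds named here.

Measured compounds:

Compound 1, `COc1c(Br)cccc1C(=O)Nc1ccc(Sc2nc3ccccc3s2)c(Cl)c1`: 10000 nM
Compound 2, `O=C(Nc1ccc(Sc2nc3ccccc3s2)c(Cl)c1)c1cccc(Br)c1O`: 22000 nM
Compound 3, `COc1ccc(S(=O)(=O)Nc2ccc3oc(-c4ccc(NC(=O)c5cccc(C)c5[N+](=O)[O-])cc4)nc3c2)cc1`: 1500 nM

These three compounds were tested in a functional assay on DLD-1 cells (Homo sapiens) for cytotoxicity, read by resazurin assay, with a stated time of 48 h; on this read-out lower numbers stand for an effect already at smaller amounts and higher numbers for an effect only at larger amounts of compound. Among them, compound 1 gives the second highest number: compound 2 lies nearest, with a 2.2-fold higher number from compound 1 to compound 2 (0.34 log units; beyond the scatter), while compound 3 is the furthest away, with a clearly lower number.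

Compound 4, `COc1c(Br)cccc1C(=O)Nc1ccc(Sc2nc3ccccc3s2)cc1`, has not yet been measured. It differs from compound 1 in one place: hydrogen in place of chloro on an aromatic carbon. Going by the values given here, the single measured step, from compound 1 to compound 2, concerns a different change, the exchange of a methyl for a hydrogen on an oxygen, and was only modest in size; it says nothing direct about taking away a chloro group from the ring that carries the amide nitrogen. Among the compounds with values here, no other measured pair touches this change. With nothing to lean on, the expectation is a step of small size in this assay, with no firm direction, and compound 4 is estimated to end near where compound 1 stands, with a 1.3-fold higher number from compound 1 to compound 4 (0.11 log units; within the scatter). The estimate for compound 4 is 13000 nM, within a range from 4000 nM to 40000 nM.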

Compound 4, half-maximal effective concentration: 40000 nM
Estimate against measurement, compound 4: 3.1-fold (0.49 log units) below, within the range that was stated.
By their numbers in this assay, from the lowest: compound 3; then compound 1; then compounds 2 and 4 (each within the scatter of the next).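

The earlier compounds shown here gave no reading at this aromatic carbon, ortho to a large group and meta to a large group. In this assay, hydrogen in place of chloro here gives a 4.0-fold higher number from compound 1 to compound 4 (0.60 log units; beyond the scatter) and shows that this position is not indifferent: for this pair, the compound carrying the chloro acts at the smaller amount. Nothing available here accounts for the step or tells what the chloro contributes.

From the compounds shown here alone, the reading rests on this one pair, so it remains open whether taking away the chloro from compound 2, with its hydrogen on the oxygen, would give a step of similar size. Going by these compounds, it also remains open where a fluoro, a methoxy, an amine or a nitrile on this same carbon would fall relative to chloro and hydrogen.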